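A few compounds are considered here, and "the series" means these few. Any claim that something is new, unique, unknown or untested is made for them only; others in the source may bear on it.

Measured so far, in an ADME assay on S9 fraction from liver (Rattus norvegicus) for metabolic stability, read by LC-MS, using NADPH, with a stated time of 30 min; on this read-out lower numbers stand for a less stable compound and higher numbers for a more stable compound:
Compound 1, `CCCCCCCCc1ccc(OCC(=O)Cn2nnc(-c3ccccc3Cl)n2)cc1`: 28%.
Compound 2, `CCCCCCCCc1ccc(OCC(=O)Cn2nnc(C(=O)OC)n2)cc1`: < 5%, which is a limit of the assay and not a number.

Going by the values given here, compound 1 holds the only numbered value in this assay; compound 2 sits at the limit of < 5% in this assay, at which 1 of the 2 values shown sits. Among the compounds with values here, the single measured step, a number at least 23 percentage points lower from compound 1 to compound 2 (beyond the scatter), therefore runs from a number down to a limit, and its full size is not known. Compound 3, `CCCCCCCCc1ccc(OCC(=O)Cn2nnc(-c3ccc(C(=O)O)cc3)n2)cc1`, has not yet been measured. It differs from compound 1 in one place: 4-carboxyphenyl in place of 2-chlorophenyl on an aromatic carbon. The measured step swaps the same 2-chlorophenyl for a different group, so it bears on compound 3 only loosely: it shows that what sits on this aromatic carbon can shift the read-out beyond the scatter. Within the data shown here, no measured compound carries a 4-carboxyphenyl, so the direction for compound 3 is uncertain. The estimated step of a number 4 percentage points higher from compound 1 to compound 3 (within the scatter) is expected to stay close to the scatter. Compound 3 is accordingly estimated at 32%, with a wide range from 8% to 65%.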

Compound 3, percent of the compound remaining: < 5%
Compound 3 was reported as a limit (the forecaster's own chance of this, stated with the estimate: 10%); middle value at least 27 percentage points away from the limit.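

Keeping a six-membered aromatic ring of carbon on this aromatic carbon of the five-membered ring is not enough to hold the read-out in this assay, where the change from 2-chlorophenyl to 4-carboxyphenyl gives a number at least 23 percentage points lower from compound 1 to compound 3 (beyond the scatter), so the earlier loss with methoxycarbonyl, a group without such a ring, was not the only loss at this place. Going by these compounds, compound 3 gives < 5%, which is a limit of the assay and not a number, so the full size of this step stays unknown. The step between compound 2 and compound 3 cannot be read because both compounds stand at the same limit: the limit of < 5% in this assay, at which 2 of the 3 values shown sit.

The compounds shown leave open whether the chlorine of compound 1 supports its read-out or whether the carboxylic acid of compound 3 lowers it, and an unsubstituted phenyl group on this carbon would help separate the two. Also open, on these data alone, is how a phenyl ring carrying an amine or an amide would behave here, as would the methyl ester of the carboxylic acid.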